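Stereoisomer series: configuration swaps at the bicyclic core

The compounds below may be only part of what the source reports. "The series", "measured", "known", "first", "only" and "open" are said of these compounds alone.

Measured so far:
- compound 1 `C[C@@H]1CN(CCCN(C(=O)Nc2cc(Cl)nc(Cl)c2)[C@H]2CC[C@@]3(c4cnc(CN)s4)C[C@@H]23)[C@@H](C)CN1` — 20%
- compound 2 `C[C@@H]1CN(CCCN(C(=O)Nc2cc(Cl)nc(Cl)c2)[C@H]2CC[C@]3(c4cnc(CN)s4)C[C@H]23)[C@@H](C)CN1` — 16%
- compound 3 `C[C@@H]1CN[C@@H](C)CN1CCCN(C(=O)Nc1cc(Cl)nc(Cl)c1)[C@H]1CC[C@@]2(c3cnc(CN)s3)C[C@@H]12` — 26%

In a functional assay on the whole organism with Mus musculus as the target, at a dose of 30 mg/kg by the oral route (a higher number here means more inhibition at the dose given (going by the name of the read-out), a lower number less inhibition), compound 3 gives 26%; the figures of compound 1 and compound 2 both lie within the scatter of it, so no order among the three can be read. The measured steps are all configurational: a number 4 percentage points lower from compound 1 to compound 2 (within the scatter), a number 6 percentage points higher from compound 1 to compound 3 (within the scatter) and a number 10 percentage points higher from compound 2 to compound 3 (within the scatter), each supported by the fact that compounds 1 and 2 differ only in the configuration as drawn, the fact that compounds 1 and 3 differ only in the configuration as drawn and (the fact that compounds 2 and 3 differ only in the configuration as drawn).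

Compound 4 `C[C@@H]1CN[C@@H](C)CN1CCCN(C(=O)Nc1cc(Cl)nc(Cl)c1)[C@H]1CC[C@]2(c3cnc(CN)s3)C[C@H]12` is the next member. The change from compound 3: the two compounds have the same atoms and bonds and differ only in configuration as drawn: 2 of 5 stereo elements differ; a stereocentre at a saturated ring carbon is drawn R in compound 3 and S in compound 4; a stereocentre at a saturated ring carbon is drawn R in compound 3 and S in compound 4. Going by the values given here, this is the same kind of swap as the one separating compound 1 from compound 2, two stereocentres at saturated ring carbons turned from R to S, and that step stayed within the scatter. Among the compounds with values here, the single change involving the other pair of centres, from compound 1 to compound 3, also stayed within the scatter.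

No step beyond the scatter is therefore expected in this assay; compound 4 is estimated at 21% (range 8% to 34%), which means an expected step of a number 5 percentage points lower from compound 3 to compound 4 (within the scatter).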

Compound 4, a percentage reported as inhibition, in the whole organism at one dose (the size of the read-out at that dose, not a potency): 39%
For compound 4 the middle estimate is 18 percentage points below the measured one; the whole stated range lies below it.
By their numbers in this assay, from the lowest: compounds 2, 1 and 3 (each within the scatter of the next); then compound 4.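

In this assay, turning the two saturated ring carbons from R to S now gives a step beyond the scatter, a number 13 percentage points higher from compound 3 to compound 4 (beyond the scatter), whereas the same kind of swap stayed within the scatter in a number 4 percentage points lower from compound 1 to compound 2 (within the scatter). The other pair of centres behaves likewise, within the scatter in a number 6 percentage points higher from compound 1 to compound 3 (within the scatter) but beyond it in a number 23 percentage points higher from compound 2 to compound 4 (beyond the scatter), so among these compounds the reading for each pair depends on how the other pair is drawn. Both swaps together give a number 19 percentage points higher from compound 1 to compound 4 (beyond the scatter), and only configuration separates these two compounds: the fact that compounds 1 and 4 differ only in the configuration as drawn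

The single-dose read-out of this assay leaves open how the stereoisomers rank in potency. Also open, from the compounds shown here alone, is whether the configuration of compound 4 keeps its lead when a carboxylic acid replaces the dichloropyridine-bearing urea or a longer chain replaces the present one.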